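The source may report more compounds than this note shows. Statements on the series, on what has been measured and on what is new or still open speak of the compounds shown alone.

In a functional assay on MDA-MB-231 cells (Homo sapiens) for cytotoxicity, read by MTT assay, with a stated time of 24 h (a lower number here means a stronger inhibitor, a higher number a weaker inhibitor), compound 1 (`CCCCCCCC/C=C\CCCCCCCC(=O)Nc1nnc(S[C@@H]2O[C@H](COC(C)=O)[C@H](OC(C)=O)[C@H](OC(C)=O)[C@H]2OC(C)=O)s1`) gives 23600 nM and compound 2 (`CCCCCC(=O)Nc1nnc(S[C@@H]2O[C@H](COC(C)=O)[C@H](OC(C)=O)[C@H](OC(C)=O)[C@H]2OC(C)=O)s1`) gives 25400 nM while compound 3 (`CCCCCCCC/C=C\CCCCCCCCCCCC(=O)Nc1nnc(S[C@@H]2O[C@H](COC(C)=O)[C@H](OC(C)=O)[C@H](OC(C)=O)[C@H]2OC(C)=O)s1`) gives 25300 nM so compound 3 stands level with the other two, within the scatter of both. The three share one core and differ in the chain on the amide carbonyl. Compound 4 (`CCCCCCCCCCCCCCCC(=O)Nc1nnc(S[C@@H]2O[C@H](COC(C)=O)[C@H](OC(C)=O)[C@H](OC(C)=O)[C@H]2OC(C)=O)s1`) is reached from compound 3 by a single change (butyl in place of dec-1-en-1-yl on a saturated chain carbon, ten or more bonds along the chain from a carbonyl carbon) with butyl in place of dec-1-en-1-yl on a saturated chain carbon, ten or more bonds along the chain from a carbonyl carbon. Going by the values given here, the one measured step within this chain is a 1.1-fold higher number from compound 1 to compound 2 (0.03 log units; within the scatter) and it stayed within the scatter even though dodec-3-en-1-yl gave way to hydrogen. No step beyond the scatter is therefore expected in this assay and the data favour no direction. The expected step is small (a 1.0-fold lower number from compound 3 to compound 4 (0.01 log units; within the scatter)) and lies within the scatter. For compound 4 the estimated value is 25000 nM with an expected range from 15000 nM to 40000 nM around that estimate.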

Compound 4, half-maximal inhibitory concentration: 25400 nM
Beside the measured number, compound 4's estimate is 1.0-fold (0.01 log units) below it, within the range that was stated.
By their numbers in this assay, from the lowest: compounds 1, 3, 2 and 4 (each within the scatter of the next).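

In this assay, butyl in place of dec-1-en-1-yl on a saturated chain carbon, ten or more bonds along the chain from a carbonyl carbon, removes the double bond from the long chain and gives a 1.0-fold higher number from compound 3 to compound 4 (0.00 log units; within the scatter). The long saturated chain also stands level with the shorter saturated chain, at no change at the digits printed from compound 2 to compound 4 (within the scatter), and with the shorter unsaturated chain, at a 1.1-fold higher number from compound 1 to compound 4 (0.03 log units; within the scatter), so neither chain length nor the double bond moves the number beyond the scatter across these four compounds. Nothing available explains this flat response.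

On these data alone, all four chains are plain hydrocarbons, so the effect of an amine or a carboxylic acid on the chain remains open. As far as these compounds go, whether a phenyl ring in place of the chain would also leave the number level is equally open.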